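The source may report more compounds than this note shows. Statements on the series, on what has been measured and on what is new or still open speak of the compounds shown alone.

compound 1 `Cc1cn(/C=C/C=O)c(=O)[nH]c1=O` gives 25000 nM
compound 2 `O=C/C=C/n1cc(F)c(=O)[nH]c1=O` gives 40000 nM
compound 3 `O=C/C=C/n1cc(C(F)(F)F)c(=O)[nH]c1=O` gives 80000 nM
compound 4 `CC(=O)/C=C/n1cc(C)c(=O)[nH]c1=O` is not yet measured

In a functional assay on HeLa cells (Homo sapiens) for inhibition (a lower number here means a stronger inhibitor, a higher number a weaker inhibitor), the numbers show a 1.6-fold higher number from compound 1 to compound 2 (0.20 log units; within the scatter) and a 3.2-fold higher number from compound 1 to compound 3 (0.51 log units; beyond the scatter), which places compound 1 at the low end of the set. Compound 4 differs from compound 1 by methyl in place of hydrogen on a carbonyl carbon, formyl to acetyl. The measured steps all swap a group on an aromatic carbon, so none tests this carbonyl carbon directly. They serve only as a rough guide to size, the remaining one being a 2.0-fold higher number from compound 2 to compound 3 (0.30 log units; within the scatter). A small step is therefore expected in this assay, with only a slight lean towards a higher number and no firm direction from the data. The expected change is a 1.4-fold higher number from compound 1 to compound 4 (0.15 log units; within the scatter). For compound 4 the estimate is 35000 nM, with an expected range of 13000 nM to 95000 nM.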

Compound 4, half-maximal inhibitory concentration: > 100000 nM
Compound 4: only a limit was reported; the forecaster's own chance of this, stated with the estimate: 15%; at least 2.8-fold (0.45 log units) between middle value and limit.
By their numbers in this assay, from the lowest: compounds 1, 2 and 3 (each within the scatter of the next, the first and the last beyond it). At a limit, above all of these: compound 4.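

In this assay compound 4 gives only a limit, > 100000 nM. Methyl in place of hydrogen on the carbonyl carbon, formyl to acetyl, is the first change shown at this position, and it gives an at least 4.0-fold higher number from compound 1 to compound 4 (0.60 log units; beyond the scatter), so this position responds to a single added carbon. The true size of that step remains unknown, as the value marks only the end of the assay's range: the limit of > 100000 nM in this assay, at which 1 of the 4 values shown sits.

The compounds shown leave open whether a longer chain such as ethyl, or a carboxylic acid, on this carbonyl carbon would give a similar result. They also leave open how acetyl behaves with fluoro or trifluoromethyl on the aromatic carbon.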